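Aryl ester variation at the tertiary acetate of the core

The source may report more compounds than this note shows. Statements on the series, on what has been measured and on what is new or still open speak of the compounds shown alone.

The shared core, represented by compound 1 `C=C1[C@H](OC(C)=O)[C@@H](OC(C)=O)[C@@H](OC(C)=O)C(C)(C)/C=C/[C@H](C)[C@H](OC(=O)c2ccccc2)[C@@]2(O)C[C@@](C)(OC(C)=O)[C@H](OC(C)=O)[C@@H]2[C@H]1OCC(C)C`, carries a methyl on the carbonyl carbon of one ester; in a functional assay on MCF7 cells (Homo sapiens) for antiproliferative activity, read by MTT assay, with a stated time of 48 h (on this read-out higher numbers stand for weaker inhibition and lower numbers for stronger inhibition), compound 1 gives 74300 nM. Compound 2 `C=C1[C@H](OC(C)=O)[C@@H](OC(C)=O)[C@@H](OC(C)=O)C(C)(C)/C=C/[C@H](C)[C@H](OC(=O)c2ccccc2)[C@@]2(O)C[C@@](C)(OC(=O)c3ccncc3)[C@H](OC(C)=O)[C@@H]2[C@H]1OCC(C)C` gives only a limit in this assay, > 100000 nM. For the measured compounds named here, the sole measured step, an at least 1.3-fold higher number from compound 1 to compound 2 (0.12 log units; that floor lies within the scatter), rests on that limit (the limit of > 100000 nM in this assay, at which 1 of the 2 values shown sits). Compound 3 `C=C1[C@H](OC(C)=O)[C@@H](OC(C)=O)[C@@H](OC(C)=O)C(C)(C)/C=C/[C@H](C)[C@H](OC(=O)c2ccccc2)[C@@]2(O)C[C@@](C)(OC(=O)c3cccc(C)c3)[C@H](OC(C)=O)[C@@H]2[C@H]1OCC(C)C` differs from compound 2 by 3-methylphenyl in place of pyridin-4-yl on a carbonyl carbon. Going by the values given here, no measured step bears on this exchange, so no shift beyond the scatter is expected, a number no higher from compound 2 to compound 3 (the limit leaves the size open). Compound 3 is estimated at 100000 nM, between 40000 nM and 250000 nM.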

Compound 3, half-maximal inhibitory concentration: > 100000 nM
Compound 3 ended at the assay's limit; the forecaster's own chance of this, stated with the estimate: 50%; the middle value lies on the limit itself.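

A second aryl ester, now with a ring of carbon only, also ends at a limit in this assay, so the outcome seen with pyridin-4-yl is not confined to that ring. Against the acetate, 3-methylphenyl in place of methyl on the carbonyl carbon gives an at least 1.3-fold higher number from compound 1 to compound 3 (0.12 log units; that floor lies within the scatter), so neither aryl ester has a step shown beyond the scatter. The step between the two aryl esters cannot be read: the limit of > 100000 nM in this assay, at which 2 of the 3 values shown sit.

On these data alone, whether a longer alkyl chain, or an aryl ring bearing an amine or a carboxylic acid, would give a measurable value on this carbonyl carbon stays open.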